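Dropping one chloro from compound 2: what to expect

The source may hold more compounds than are shown below. What is called first, only, known or untested is meant among the compounds shown, and "the series" means these compounds.

Measured compounds:
compound 1, `ClCc1ccc(Cn2cnc3c(Cl)ncnc32)cc1`, 640 nM
compound 2, `ClCc1cccc(Cn2cnc3c(Cl)nc(Cl)nc32)c1`, 5880 nM
compound 3, `ClCc1ccc(Cn2cnc3ncnc(Cl)c32)cc1`, 4460 nM

Of the compounds shown here, three have been tested in a functional assay on CAKI-1 cells (Homo sapiens) for cytotoxicity, read by sulforhodamine B assay, with a stated time of 48 h; on this read-out lower numbers stand for stronger inhibition of growth and higher numbers for weaker inhibition of growth. Compound 2 gives the highest number of the three, so it is the weakest inhibitor of growth here. Its nearest neighbour is compound 3, whose number lies within the scatter of that of compound 2, so no order between these two can be claimed. Compound 1, by contrast, lies well beyond the scatter below compound 2, and is the strongest of the three.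

Compound 4, `ClCc1cccc(Cn2cnc3c(Cl)ncnc32)c1`, has not yet been measured. It differs from compound 2 in one place: hydrogen in place of chloro on an aromatic carbon. The core thus keeps a single chloro group, as in compound 1.

Among the compounds with values here, no directly comparable step between measured compounds is available, so the expectation rests on compound 1, which with a single chloro on its core gives 640 nM, and on the weak compound 2. The step of a 2.9-fold lower number from compound 2 to compound 4 (0.47 log units; beyond the scatter) is expected to run toward a lower number, beyond the scatter but short of reaching compound 1. Compound 4 is therefore estimated at 2000 nM, with a likely range from 600 nM to 6500 nM.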

Compound 4, concentration for total growth inhibition: 2950 nM
Compound 4: middle estimate off by 1.5-fold (0.17 log units), on the low side; measured number inside the range.
By their numbers in this assay, from the lowest: compound 1; then compounds 4, 3 and 2 (each within the scatter of the next).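

Within the data shown here, the earlier compounds offered no pair differing in one place, so this is the first direct look at the aromatic carbon between two ring nitrogen atoms: in this assay, putting hydrogen in place of chloro there gives a 2.0-fold lower number from compound 2 to compound 4 (0.30 log units; within the scatter) and so cannot be told apart from the ordinary spread of repeated measurements. On this one pair, then, the chloro group at this position shows no measurable bearing on growth inhibition, and no order between the two compounds can be claimed. Nothing available here explains this result or shows how these compounds act on the cells.

From the compounds shown here alone, whether this carbon would respond to a different kind of group stays open: an amine, a methoxy group or a longer chain in place of the hydrogen of compound 4 might give a number clearly apart from it, or might not. Going by these compounds, the finding also rests on a single pair, so whether chloro and hydrogen would again read alike starting from compound 1 at 640 nM remains unknown.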